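The source may hold more compounds than are shown below. What is called first, only, known or untested is meant among the compounds shown, and "the series" means these compounds.

Compound 2 `O=C(O)c1ccc(CN2C(=O)S/C(=C\c3ccccc3)C2=O)cc1` stands at the lower of the two numbers recorded in a functional assay on HT-29 cells (Homo sapiens) for cytotoxicity, read by MTT assay, with a stated time of 24 h (a lower number here means a stronger inhibitor, a higher number a weaker inhibitor), giving 88000 nM, while compound 1 `O=C(O)c1ccc(CN2C(=O)S/C(=C\c3cccnc3)C2=O)cc1` gives 90000 nM; the step of a 1.0-fold lower number from compound 1 to compound 2 (0.01 log units; within the scatter) lies within the scatter, so the two are not truly separated. Compound 3 `O=C(O)c1ccc(CN2C(=O)S/C(=C\c3ccccn3)C2=O)cc1` is not yet measured and differs from compound 2 by pyridin-2-yl in place of phenyl on a double-bonded chain carbon bound to a double-bonded ring carbon. Going by the values given here, the only measured step that bears on this, a 1.0-fold lower number from compound 1 to compound 2 (0.01 log units; within the scatter), put phenyl in place of pyridin-3-yl and moved nothing beyond the scatter, so the step of a 1.0-fold higher number from compound 2 to compound 3 (0.01 log units; within the scatter) is expected to be none beyond the scatter. Compound 3 is therefore estimated at 90000 nM, within 45000 nM to 180000 nM.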

Compound 3, half-maximal inhibitory concentration: 78000 nM
For compound 3 the middle estimate is 1.2-fold (0.06 log units) above the measured one; measured number inside the range.
By their numbers in this assay, from the lowest: compounds 3, 2 and 1 (each within the scatter of the next).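

In this assay, pyridin-2-yl now joins phenyl and pyridin-3-yl on the double-bonded chain carbon: pyridin-2-yl in place of phenyl gives (a 1.1-fold lower number from compound 2 to compound 3 (0.05 log units; within the scatter)), and pyridin-2-yl in place of pyridin-3-yl gives (a 1.2-fold lower number from compound 1 to compound 3 (0.06 log units; within the scatter)). These three rings therefore cannot be told apart at this position, whether the ring holds a nitrogen or not, and in neither of the two pyridinyl forms does it separate from phenyl. No measurement at hand offers an explanation for this. Still open, as far as these compounds go, is whether a phenyl carrying an amine or a methoxy group would move the number beyond the scatter. The same question stands for a non-aromatic group such as a longer chain.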